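The source may report more compounds than this note shows. Statements on the series, on what has been measured and on what is new or still open speak of the compounds shown alone.

Measured compounds:
compound 1, `O=C(CN1CCN(c2nnc(Cc3ccncc3)c3ccccc23)CC1)Nc1ccc(Br)cc1`, 2710 nM
compound 2, `O=C(CN1CCN(c2nnc(Cc3ccccc3)c3ccccc23)CC1)Nc1ccc(Br)cc1`, 2000 nM
compound 3, `O=C(CN1CCN(c2nnc(Cc3ccccc3)c3ccccc23)CC1)Nc1cccc(Br)c1`, reported as "not active" (no number reported), without a number

Going by the values given here, in a functional assay on A549 cells (Homo sapiens) for cytotoxicity, read by MTT assay, with a stated time of 72 h (on this read-out lower numbers stand for stronger inhibition and higher numbers for weaker inhibition), compound 1 and compound 2 lie within the usual scatter of each other, so neither can be called the more potent; the only measured step, a 1.4-fold lower number from compound 1 to compound 2 (0.13 log units; within the scatter), concerns a group on a saturated chain carbon and does not touch the amide-type nitrogen. Compound 3 differs from compound 2 only at the bromophenyl group on that nitrogen and is reported as not active, which shows that this part of the molecule matters, although no number is available to size the effect.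

Compound 4, `O=C(CN1CCN(c2nnc(Cc3ccncc3)c3ccccc23)CC1)Nc1c(F)cccc1F`, changes exactly this part: 2,6-difluorophenyl in place of 4-bromophenyl on an amide-type nitrogen. Among the compounds with values here, no measured step bears directly on it. The change is larger than a shift of one bromine, and the result for compound 3 warns that this position can cost activity, so a weaker number is expected, with wide uncertainty, and a real chance that only "not active" is reported. Compound 4 is estimated at 5500 nM in this assay, between 1500 nM and 25000 nM, meaning an expected step of a 2.0-fold higher number from compound 1 to compound 4 (0.31 log units; beyond the scatter).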

Compound 4, half-maximal inhibitory concentration: 54400 nM
The estimate for compound 4 lay 9.9-fold (1.00 log units) below the measured number, outside the stated range (above it).
By their numbers in this assay, from the lowest: compounds 2 and 1 (each within the scatter of the next); then compound 4.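

In this assay, going by these compounds alone, replacing 4-bromophenyl with 2,6-difluorophenyl on the amide-type nitrogen gives a 20-fold higher number from compound 1 to compound 4 (1.30 log units; beyond the scatter) and so puts the first number on a change at this position. Compound 3 showed that the group on this nitrogen matters, but its "not active" result could not show how much. The step here is large, whereas the change on the saturated chain carbon gave only a 1.4-fold lower number from compound 1 to compound 2 (0.13 log units; within the scatter). Nothing measured here explains the loss.

On these data alone, it remains open whether the loss follows from removing the bromine or from adding the two fluorines. It is also unknown how the aromatic ring on this nitrogen would behave if it carried an amine or a carboxylic acid, or if a longer carbon chain replaced it.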